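The compounds below may be only part of what the source reports. "The series", "measured", "known", "first", "only" and "open" are said of these compounds alone.

Compound 1 `CC[C@@H](Nc1c(C#N)c(-c2ccc(-c3ccccc3F)cc2)nc2cnccc12)C(N)=O`: 2.7
Compound 2 `CCOc1ccccc1-c1ccc(-c2nc3cnccc3c(NC(COC)C(N)=O)c2C#N)cc1`: 2.8

In a physicochemical assay for lipophilicity, read by HPLC, at pH 7.5 (a lower number here means a more polar compound, a higher number a more lipophilic compound), compound 1 gives 2.7 and compound 2 gives 2.8; the two numbers lie within the usual scatter of each other, so neither compound can be called the more polar. Compound 3 `CC[C@@H](Nc1c(C#N)c(-c2ccc(-c3cccc(OC)c3)cc2)nc2cnccc12)C(N)=O` has not been measured in this assay. It differs from compound 1 in one place: 3-methoxyphenyl in place of 2-fluorophenyl on an aromatic carbon. Among the measured compounds shown here, no measured pair shows this exact change, so the expected step from compound 1 to compound 3 is small, if anything a slight move toward the polar side, and likely within the scatter. Compound 3 is therefore estimated at 2.6, with a range from 2.3 to 2.9, an expected step of a number 0.10 log units lower from compound 1 to compound 3 (within the scatter).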

Compound 3, distribution coefficient: 2.7
Compound 3: the middle estimate sits 0.10 log units below what was measured; measured number inside the range.
By their numbers in this assay, from the lowest: compounds 1, 3 and 2 (each within the scatter of the next).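

In this assay, putting 3-methoxyphenyl in place of 2-fluorophenyl on an aromatic carbon, para to a large group, gives no change at the digits printed from compound 1 to compound 3 (within the scatter). Among the compounds shown here, this is the first comparison of compounds that differ in one place, and it shows that this exchange, in which the entering group counts a hydrogen-bond acceptor and the leaving group none, leaves the reading within the scatter. No measurement shown here offers an explanation for this result. As far as these compounds go, whether an amine or a carboxylic acid on this ring would shift the number stays open. So does the effect of a longer chain in place of the methoxy group.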